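Swapping a Hydrazone-Derived Arm for 2-Methylphenyl

The source may report more compounds than this note shows. Statements on the series, on what has been measured and on what is new or still open speak of the compounds shown alone.

Of the compounds shown here, two built on one shared core have been tested so far. Compound 1 `Cc1c(-n2c(N)c(C(N)=O)c(-c3ccccc3)c2-c2ccccc2)n(C)n(-c2ccccc2)c1=O` carries an amine and a primary amide on its five-membered ring; in a functional assay on the whole organism (strain Sprague-Dawley) for inhibition, with Rattus norvegicus as the target, read by paw edema, with stated times of 1 h and 3 h, at a dose of 70 mg/kg by the subcutaneous route (a lower number here means less inhibition, a higher number more inhibition at the dose given (going by the name of the read-out)), compound 1 gives 47.8%. Compound 2 `Cc1c(-n2c(-c3ccccc3)c(-c3ccccc3)c3c(N/N=C/c4ccccc4)ncnc32)n(C)n(-c2ccccc2)c1=O` instead carries a fused bicyclic system bearing a benzylidene hydrazine arm; in this assay compound 2 gives 90.8%. Compound 2 therefore stands highest of the two numbers, and its gap to compound 1 lies beyond the scatter.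

Compound 3 `Cc1ccccc1Nc1ncnc2c1c(-c1ccccc1)c(-c1ccccc1)n2-c1c(C)c(=O)n(-c2ccccc2)n1C` has not yet been measured. It differs from compound 2 in one place: a group of 7 heavy atoms (7 carbon; one six-membered aromatic ring of carbon only) in place of a group of 8 heavy atoms (7 carbon, 1 nitrogen; one six-membered aromatic ring of carbon only), on a nitrogen on an aromatic ring. Within the data shown here, no step between measured compounds matches this change, so there is nothing to calibrate it against. On the numbers available, a moderate fall is expected rather than a gain, since compound 2 already sits near the top of the scale in this assay. The expected step is a number 18.8 percentage points lower from compound 2 to compound 3 (beyond the scatter). Compound 3 is estimated at 72%, with a range from 48% to 90%.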

Compound 3, a percentage reported as inhibition, in the whole organism at one dose (the size of the read-out at that dose, not a potency): 13.3%
Compound 3: middle estimate off by 58.7 percentage points, on the high side; measured number outside the range, below it.
By their numbers in this assay, from the lowest: compound 3; then compound 1; then compound 2.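

Putting 2-methylphenyl in place of the benzylidene hydrazine arm, on this nitrogen on an aromatic ring, gives a number 77.5 percentage points lower from compound 2 to compound 3 (beyond the scatter) in this assay, so the group at this position strongly affects the read-out. Both groups hold a six-membered aromatic ring of carbon only, so that ring alone does not keep the inhibition high; the arm that leaves also has a nitrogen and a double bond outside aromatic rings, and 2-methylphenyl has neither. Nothing available explains the size of this step.

This single swap changes several features at once, so the compounds shown cannot separate the part played by the arm's nitrogen, its double bond or the methyl group of 2-methylphenyl. On these data alone, how a benzyl group or a short alkyl chain on this nitrogen would read out in this assay remains open.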